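This account rests on a few compounds, and the source may have more. Where it says the series, first, only, none or still open, it means among the compounds named here.

Measured in a physicochemical assay for solubility, in phosphate buffer, at pH 7.4; on this read-out lower numbers stand for lower solubility and higher numbers for higher solubility (both entries are limits, not numbers):
- Compound 1 `CCOC(=O)c1c(-c2ccc(Cl)cc2)[nH]c2cccc(OC)c2c1=O`: > 100000 nM
- Compound 2 `CCOC(=O)c1c(-c2ccccc2)[nH]c2cccc(OC)c2c1=O`: > 100000 nM

Compound 2 stands at > 100000 nM, which is a limit of the assay and not a number. Compound 3 `CCOC(=O)c1c(-c2cccc(Cl)c2)[nH]c2cccc(OC)c2c1=O` carries chloro in place of hydrogen on an aromatic carbon, meta to a large group: chloro in place of hydrogen on an aromatic carbon. Among the compounds with values here, one measured step bears on this change, a step that the two limits leave unreadable from compound 1 to compound 2, and it has no readable size. The evidence on it is the limit of > 100000 nM in this assay, at which 2 of the 2 values shown sit. No step beyond the scatter is therefore expected in this assay, in either direction. For compound 3 the estimated value is 100000 nM, with an expected range from 40000 nM to 200000 nM. The expected size is a number no higher from compound 2 to compound 3 (the limit leaves the size open).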

Compound 3, solubility: > 100000 nM
Compound 3: no number, only a limit; the forecaster's own chance of this, stated with the estimate: 80%; the middle value lies on the limit itself.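

In this assay compound 3 gives > 100000 nM, which is a limit and not a number. Within the data shown here, no step among compound 1, compound 2 and compound 3 can therefore be read. The compounds shown leave open what number each would give, and whether chloro in place of hydrogen, at either position, shifts that number at all.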